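Phenylethynyl for phenylethenyl on two amide cores

The source may report more compounds than this note shows. Statements on the series, on what has been measured and on what is new or still open speak of the compounds shown alone.

In a functional assay on NIH3T3 cells for agonist activity at Urotensin-2 receptor (Homo sapiens), with a stated time of 5 days (on this read-out lower numbers stand for smaller maximal responses and higher numbers for larger maximal responses), compound 3 `Cc1ccc(C(CCN(C)C)NC(=O)/C=C/c2ccccc2)cc1` gives 97% and compound 1 `Cc1ccc(C(CCN(C)C)NC(=O)C#Cc2ccccc2)cc1` gives 131%. The step of a number 34 percentage points higher from compound 3 to compound 1 (beyond the scatter) is the change (2-phenylethynyl in place of 2-phenylethenyl on a carbonyl carbon). Compound 2 `CN(C)CCC(NC(=O)/C=C/c1ccccc1)c1ccc2ccccc2c1` carries another core; how the core of compound 2 differs from that of compound 3 is not broken down here. In this assay compound 2 gives 116%, which lies above the value of compound 3 and below that of compound 1, both gaps beyond the usual scatter. For the measured compounds named here, compound 4 `CN(C)CCC(NC(=O)C#Cc1ccccc1)c1ccc2ccccc2c1` is not yet measured; it differs from compound 2 by 2-phenylethynyl in place of 2-phenylethenyl on a carbonyl carbon, the same change, at the same place, as the one made from compound 3 to compound 1. In this assay, going by the values given here, a step of a number 24 percentage points higher from compound 2 to compound 4 (beyond the scatter) is expected, somewhat smaller than the earlier one because the single measured step of a number 34 percentage points higher from compound 3 to compound 1 (beyond the scatter) rests on one core only and its transfer to the second core is untested. For compound 4 the estimate in this assay is 140%, expected to fall between 115% and 165%.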

Compound 4, largest response reached (reported as efficacy), in percent of the reference or control that the assay uses: 115%
Compound 4: middle estimate off by 25 percentage points, on the high side, within the range that was stated.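

In this assay, 2-phenylethynyl in place of 2-phenylethenyl on a carbonyl carbon gives a number 1 percentage points lower from compound 2 to compound 4 (within the scatter), so the rise seen on the core of compound 1 does not reappear on the core of compound 4. The result of this change therefore depends on the core in these two pairs and cannot be carried over from one to the other as a fixed increment: the same change on two cores in this assay, a number 34 percentage points higher (beyond the scatter) from compound 3 to compound 1 and a number 1 percentage points lower (within the scatter) from compound 2 to compound 4, 35 percentage points apart, beyond the scatter of two such steps
For the compounds shown here, this does not show which difference between the cores sets the outcome, and with only one pair per core it gives no rule for predicting the step on a third core.

Still open, from the compounds shown here alone, is how a saturated 2-phenylethyl group on the carbonyl carbon would read on each of the two cores, which would show whether the core dependence is specific to the triple bond. Also open, going by these compounds, is whether the same difference between cores persists with a secondary amine or a longer chain in place of the dimethylamino end.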